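The compounds below may be only part of what the source reports. "The series", "measured", "known", "first", "only" and "open" are said of these compounds alone.

Working notes on the series, read in a functional assay on MCF7 cells (Homo sapiens) for antiproliferative activity, read by MTT assay, with a stated time of 72 h; a higher number here means a weaker inhibitor, a lower number a stronger inhibitor. Compound 1 (`CCNC(=O)c1cc(Oc2ccc(NC(=O)c3nn(-c4ccccc4OC(F)(F)F)c(=O)cc3C)cc2)ccn1`) gives 15500 nM, and compound 2 (`CCNC(=O)c1cc(Oc2ccc(NC(=O)c3nn(-c4cccc(F)c4)c(=O)cc3C)cc2)ccn1`) gives 18900 nM. Going by the values given here, only these two numbers exist so far, and the single measured step between them is a 1.2-fold higher number from compound 1 to compound 2 (0.09 log units; within the scatter). That step lies within the scatter, so compound 2 stands level with compound 1.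

The unmeasured compound 3 (`CCNC(=O)c1cc(Oc2ccc(NC(=O)c3nn(-c4ccc(C)cc4)c(=O)cc3C)cc2)ccn1`) carries 4-methylphenyl in place of 3-fluorophenyl on an aromatic nitrogen. Among the compounds with values here, the single measured step also exchanges the group on an aromatic nitrogen, so it is the only evidence bearing on this change. Within the data shown here, it is thin evidence, as no measured compound carries 4-methylphenyl. Exchanging 2-(trifluoromethoxy)phenyl for 3-fluorophenyl left the number within the scatter, and a similar outcome is expected here, with no step beyond the scatter. The expected step is a 1.1-fold lower number from compound 2 to compound 3 (0.05 log units; within the scatter). For compound 3 the estimated value is 17000 nM, with an expected range of 8000 nM to 36000 nM.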

Compound 3, half-maximal inhibitory concentration: 51300 nM
Compound 3: the middle estimate sits 3.0-fold (0.48 log units) below what was measured; measured number above the stated range.
By their numbers in this assay, from the lowest: compounds 1 and 2 (each within the scatter of the next); then compound 3.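

In this assay the group on the aromatic nitrogen now gives its first steps beyond the scatter: 4-methylphenyl in place of 3-fluorophenyl gives a 2.7-fold higher number from compound 2 to compound 3 (0.43 log units; beyond the scatter) and 4-methylphenyl in place of 2-(trifluoromethoxy)phenyl gives a 3.3-fold higher number from compound 1 to compound 3 (0.52 log units; beyond the scatter) as the matching reading against the other measured aryl group. The exchange between compound 1 and compound 2 had left this position looking indifferent to the aryl group, but the series is in fact modestly sensitive here, and compound 3 is the weakest inhibitor of the three, with both of its steps beyond the scatter. Nothing measured on these compounds accounts for the shift.

Compound 3 differs from compound 2 in both the substituent and where it sits on the phenyl ring, so the compounds shown cannot separate the two, and 3-methylphenyl and 4-fluorophenyl would be the groups that pull them apart. Also open, as far as these compounds go, is how far the number moves with unsubstituted phenyl, or with a ring carrying an amine or a carboxylic acid in the place of the 4-methyl group.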